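The source may hold more compounds than are shown below. What is called first, only, known or untested is meant among the compounds shown, and "the series" means these compounds.

Series notes: in an assay for inhibition of RAC-alpha serine/threonine-protein kinase (Homo sapiens), read by HTRF, with a stated time of 1 h (on this read-out higher numbers stand for weaker inhibition and lower numbers for stronger inhibition), compound 1 `Cn1ncc(Cl)c1-c1cc(C(=O)N[C@@H]2CN[C@H](CCN3CCC(O)CC3)C[C@H]2c2ccc(Cl)c(Cl)c2)oc1Cl` gives 5.99 nM and compound 2 `CCC[C@@H]1C[C@@H](c2ccc(Cl)c(Cl)c2)[C@H](NC(=O)c2cc(-c3c(Cl)cnn3C)c(Cl)o2)CN1` gives 10.4 nM; the single step of a 1.7-fold higher number from compound 1 to compound 2 (0.24 log units; within the scatter) leaves compound 2 with the higher of the two numbers, though within the scatter of compound 1. Compound 3 `Cn1ncc(Cl)c1-c1cc(C(=O)N[C@@H]2CN[C@H](CC(=O)NC3CCC3)C[C@H]2c2ccc(Cl)c(Cl)c2)oc1Cl` carries cyclobutylcarbamoyl in place of ethyl on a saturated chain carbon bound to a saturated ring carbon. Within the data shown here, the only step that bears on it is the same chain position, where a hydroxypiperidinyl group in compound 1 against methyl in compound 2 gave a 1.7-fold higher number from compound 1 to compound 2 (0.24 log units; within the scatter), so a bulkier group with a donor and an acceptor there is expected to change little: the estimate is a 1.4-fold lower number from compound 2 to compound 3 (0.14 log units; within the scatter), giving compound 3 an expected 7.5 nM with a range of 2.5 nM to 22 nM in this assay.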

Compound 3, half-maximal inhibitory concentration: 7.98 nM
The estimate for compound 3 lay 1.1-fold (0.03 log units) below the measured number, within the range that was stated.
By their numbers in this assay, from the lowest: compounds 1, 3 and 2 (each within the scatter of the next).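

In this assay, cyclobutylcarbamoyl in place of ethyl gives a 1.3-fold lower number from compound 2 to compound 3 (0.12 log units; within the scatter), and in place of (4-hydroxypiperidin-1-yl)methyl it gives a 1.3-fold higher number from compound 1 to compound 3 (0.12 log units; within the scatter). A third, different kind of group at this saturated chain carbon, now one with a four-membered ring, therefore leaves the number within the scatter of both others, so the position has so far shown no dependence on the group carried there. Nothing at hand explains this flat response. As far as these compounds go, whether a carboxylic acid or a primary amine on this chain would also leave the number within the scatter remains open.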